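Thiophene position swap on two related nucleoside cores

The compounds below may be only part of what the source reports. "The series", "measured", "known", "first", "only" and "open" are said of these compounds alone.

Compound 2 `COc1nc(N)nc2c1c(-c1cccs1)cn2[C@@H]1O[C@H](CO)[C@@H](O)[C@H]1O` carries thiophen-2-yl; in a functional assay on HCT-116 cells (Homo sapiens), read by MTT assay, with a stated time of 72 h (a lower number here means a stronger inhibitor, a higher number a weaker inhibitor), compound 2 gives > 20000 nM, which is a limit of the assay. Compound 1 `COc1nc(N)nc2c1c(-c1ccsc1)cn2[C@@H]1O[C@H](CO)[C@@H](O)[C@H]1O` differs by thiophen-3-yl in place of thiophen-2-yl on an aromatic carbon. In this assay compound 1 gives > 20000 nM, again a limit. The step that the two limits leave unreadable from compound 2 to compound 1 is thus not readable. Compound 3 `CNc1ncnc2c1c(-c1cccs1)cn2[C@@H]1O[C@H](CO)[C@@H](O)[C@H]1O` has another core; the difference between the two cores is not broken down here. In this assay compound 3 gives > 20000 nM, also a limit. All three values sit at the limit of > 20000 nM in this assay, at which 3 of the 3 values shown sit.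

Compound 4 `CNc1ncnc2c1c(-c1ccsc1)cn2[C@@H]1O[C@H](CO)[C@@H](O)[C@H]1O` is not yet measured and differs from compound 3 by thiophen-3-yl in place of thiophen-2-yl on an aromatic carbon, the same change in the same place as between compound 2 and compound 1. The step that the limit leaves unreadable from compound 3 to compound 4 is expected to be unreadable as well, since compound 1 gave > 20000 nM after the same change. Compound 4 is therefore expected near 30000 nM, between 10000 nM and 100000 nM.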

Compound 4, half-maximal inhibitory concentration: > 20000 nM
Compound 4: only a limit was reported; the forecaster's own chance of this, stated with the estimate: 85%; the middle value is on the limit's open side.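

No step can be read from compound 3 to compound 4, as both values are limits of the assay. The compounds shown leave open whether thiophen-2-yl and thiophen-3-yl differ at all in this assay, with every value at one limit: the limit of > 20000 nM in this assay, at which 4 of the 4 values shown sit.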